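Ring size of the fused bicycle and hepatocyte clearance

The source may report more compounds than this note shows. Statements on the series, on what has been measured and on what is new or still open speak of the compounds shown alone.

Compound 1 `CC(=O)N[C@@H]1CCC[C@H](C(=O)Nc2cc(-c3cnc(C)n3C(C)C)ccn2)C1`: 7.4 uL/min
Compound 2 `CC(=O)N[C@@H]1CCC[C@H](C(=O)Nc2cc(-c3cnn(C)c3C)c(Cl)cn2)C1`: 10 uL/min
Compound 3 `CC(=O)N[C@@H]1CCC[C@H](C(=O)Nc2cc(-c3cnc4n3CCCC4)c(Cl)cn2)C1`: 12 uL/min

The three measured compounds were tested in an ADME assay on cells (Hepatocyte, Rattus norvegicus) for metabolic stability, using equilibrium dialysis; on this read-out higher numbers stand for fast clearance and lower numbers for slow clearance. Compound 3 gives the highest of the three numbers, with compound 2 nearest and compound 1 furthest; both gaps lie within the scatter, so no order among them can be claimed.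

Compound 4 `CC(=O)N[C@@H]1CCC[C@H](C(=O)Nc2cc(-c3cnc4n3CCC4)c(Cl)cn2)C1` differs from compound 3 in one place: a group of 8 heavy atoms (6 carbon, 2 nitrogen; one five-membered non-aromatic ring with 1 hetero atom, one five-membered aromatic ring with 2 hetero atoms) in place of a group of 9 heavy atoms (7 carbon, 2 nitrogen; one five-membered aromatic ring with 2 hetero atoms, one six-membered non-aromatic ring with 1 hetero atom), on an aromatic carbon.

Among the compounds with values here, the only measured step touching this position is a 1.2-fold higher number from compound 2 to compound 3 (0.08 log units; within the scatter), and it stayed within the scatter. With nothing in the data pointing to a larger effect, compound 4 is expected to give a number close to that of compound 3, a 1.1-fold lower number from compound 3 to compound 4 (0.04 log units; within the scatter). Compound 4 is therefore estimated at 11 uL/min, with a range from 6 uL/min to 22 uL/min.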

Compound 4, intrinsic clearance in a liver preparation (reported as CLH), per the amount of preparation that the assay uses: 19 uL/min
The estimate for compound 4 lay 1.7-fold (0.24 log units) below the measured number; the range from low to high includes it.
By their numbers in this assay, from the lowest: compounds 1, 2, 3 and 4 (each within the scatter of the next, the first and the last beyond it).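

In this assay, the group with the five-membered non-aromatic ring gives a 1.6-fold higher number from compound 3 to compound 4 (0.20 log units; within the scatter) when it replaces the group with the six-membered non-aromatic ring, and a 1.9-fold higher number from compound 2 to compound 4 (0.28 log units; within the scatter) when it replaces the group with only the five-membered aromatic ring. At this position, ortho to the chloro group, neither exchange leaves the scatter, so changing the size of the non-aromatic ring shows no clear effect on this read-out. Nothing available here explains these numbers. From the compounds shown here alone, it remains open whether a seven-membered non-aromatic ring, or an amine or a longer chain on the five-membered aromatic ring, would give a step beyond the scatter.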